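From hydroxycarbamoyl to carboxy at the assay limit

The source may report more compounds than this note shows. Statements on the series, on what has been measured and on what is new or still open speak of the compounds shown alone.

Measured so far in a functional assay on SMMC-7721 cells (Homo sapiens) for cytotoxicity, read by MTT assay, with a stated time of 48 h; a lower number here means a stronger inhibitor, a higher number a weaker inhibitor:
- compound 1 `O=C(N[C@H]1CC[C@@]2(CC1)OC[C@]1(OO2)C2CC3CC(C2)CC1C3)c1ccc(O)c(O)c1`: > 50000 nM (a limit)
- compound 2 `O=C(NO)[C@H]1CC[C@@]2(CC1)OC[C@]1(OO2)C2CC3CC(C2)CC1C3`: > 50000 nM (a limit)

Compound 2 gives no number in this assay: its > 50000 nM is a limit of the assay. Compound 1 is no different in kind, and the two share one position: the limit of > 50000 nM in this assay, at which 2 of the 2 values shown sit. Among the compounds with values here, no step can be read between them, so the series so far offers no measured size of change.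

Compound 3 `O=C(O)[C@H]1CC[C@@]2(CC1)OC[C@]1(OO2)C2CC3CC(C2)CC1C3` is still to be measured. Relative to compound 2, it carries hydroxy in place of hydroxyamino on a carbonyl carbon, so that hydroxycarbamoyl becomes carboxy: hydroxy in place of hydroxyamino on a carbonyl carbon.

With only that limit to go on, no step beyond the usual scatter is expected in either direction, and the expected change is a number no higher from compound 2 to compound 3 (the limit leaves the size open). A report as a limit again is the likeliest outcome. For compound 3 the estimated value is 50000 nM, with an expected range of 20000 nM to 100000 nM.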

Compound 3, half-maximal inhibitory concentration: > 100000 nM
Compound 3: only a limit was reported; the forecaster's own chance of this, stated with the estimate: 85%; middle value at least 2.0-fold (0.30 log units) from the limit.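

In this assay, no step can be read from compound 2 to compound 3: both results are limits of the assay, not numbers. The compounds shown leave open whether hydroxycarbamoyl and carboxy differ at all in this assay, and which change to the shared core would give a readable value.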